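Expected Growth Inhibition of a 4-Methoxyphenyl Analogue

This account rests on a few compounds, and the source may have more. Where it says the series, first, only, none or still open, it means among the compounds named here.

- compound 1 `COc1ccc(/C=C/C(=O)/C=C/c2ccc(OCc3cn(CCOc4cc(=O)oc5ccccc45)nn3)c(OC)c2)cc1OC` gives 82% here
- compound 2 `COc1cc(/C=C/C(=O)/C=C/c2ccccc2)ccc1OCc1cn(CCOc2cc(=O)oc3ccccc23)nn1` gives 56% here
- compound 3 `COc1cc(/C=C/C(=O)/C=C/c2ccco2)ccc1OCc1cn(CCOc2cc(=O)oc3ccccc23)nn1` gives 72% here

All three values come from a functional assay on HCT-116 cells (Homo sapiens) for inhibition, read by sulforhodamine B assay, with a stated time of 48 h, tested at 50 uM (a lower number here means less inhibition of growth, a higher number more inhibition of growth at the concentration tested), and they place compound 3 in the middle of the set, level with compound 1 and clear of compound 2. The two relevant steps are a number 10 percentage points lower from compound 1 to compound 3 (within the scatter) and a number 16 percentage points higher from compound 2 to compound 3 (beyond the scatter) on the numbers shown.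

The open question is compound 4 `COc1ccc(/C=C/C(=O)/C=C/c2ccc(OCc3cn(CCOc4cc(=O)oc5ccccc45)nn3)c(OC)c2)cc1` which puts 4-methoxyphenyl in place of furan-2-yl on a double-bonded chain carbon bound to a double-bonded chain carbon at an otherwise unchanged structure. Among the measured compounds shown here, no measured compound carries this exact group. The closest evidence is the pair of compound 1 with 3,4-dimethoxyphenyl and compound 2 with phenyl, joined by a number 26 percentage points lower from compound 1 to compound 2 (beyond the scatter) in the same place. The group entering compound 4 is named between those two, so its value is expected to fall inside that interval, close to where compound 3 stands. No step beyond the scatter is therefore expected. The estimated step is a number 2 percentage points lower from compound 3 to compound 4 (within the scatter) on present evidence. In this assay compound 4 is estimated at 70% with 56% to 84% as its expected range.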

Compound 4, percent growth inhibition at one concentration: 71%
Compound 4: middle estimate off by 1 percentage points, on the low side; low and high end bracket the measured number.
By their numbers in this assay, from the lowest: compound 2; then compounds 4, 3 and 1 (each within the scatter of the next, the first and the last beyond it).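

In this assay, among the compounds shown here, the 4-methoxyphenyl group separates the two earlier aryl groups at this place, on a double-bonded chain carbon bound to a double-bonded chain carbon: the methoxy-for-hydrogen change gives a number 15 percentage points higher from compound 2 to compound 4 (beyond the scatter), and the hydrogen-for-methoxy change gives a number 11 percentage points lower from compound 1 to compound 4 (beyond the scatter), so the single large step from 3,4-dimethoxyphenyl to phenyl now resolves into two smaller steps, each beyond the scatter. The order of phenyl, 4-methoxyphenyl and 3,4-dimethoxyphenyl holds only within this aryl series, and compound 3 stands against reading it as a rule for the position, since furan-2-yl, which carries no methoxy, is not told apart from 4-methoxyphenyl, with a number 1 percentage points lower from compound 3 to compound 4 (within the scatter). Nothing available explains why these groups give these numbers.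

The compounds shown leave open whether a thiophene ring, a pyridine ring or an amine on the phenyl ring would fit the same series at this place. They also leave open whether the methoxy steps would persist in other cell lines or across a full concentration range rather than at the one concentration tested.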